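This account rests on a few compounds, and the source may have more. Where it says the series, first, only, none or still open, it means among the compounds named here.

Of the compounds shown here, three of a shared core have been tested in a functional assay on KB cells (Homo sapiens) for cytotoxicity, read by sulforhodamine B assay; a higher number here means that more compound is needed for the effect, a lower number that less compound is needed. Compound 1 `C=C1CC[C@@H]2[C@](C)(CO[Si](c3ccccc3)(c3ccccc3)C(C)(C)C)[C@H](OC(C)=O)CC[C@@]2(C)[C@@H]1C/C=C1/C(=O)OC[C@H]1O` gives 9.86 uM. Compound 2 `C=C1CC[C@@H]2[C@](C)(CO[Si](C)(C)C(C)(C)C)[C@H](OC(C)=O)CC[C@@]2(C)[C@@H]1C/C=C1/C(=O)OC[C@H]1OC(C)=O` gives 3.62 uM, and compound 3 `C=C1CC[C@@H]2[C@](C)(CO[Si](C)(C)C(C)(C)C)[C@H](O)CC[C@@]2(C)[C@@H]1C/C=C1/C(=O)OC[C@H]1OC(C)=O` gives 10.7 uM. The difference between the cores of compound 1 and compound 2 is not broken down here. Compound 3 differs from compound 2 by hydrogen in place of acetyl on an oxygen on a saturated carbon, a change that gave a 3.0-fold higher number from compound 2 to compound 3 (0.47 log units; beyond the scatter). The unmeasured compound 4 `C=C1CC[C@@H]2[C@](C)(CO[Si](c3ccccc3)(c3ccccc3)C(C)(C)C)[C@H](O)CC[C@@]2(C)[C@@H]1C/C=C1/C(=O)OC[C@H]1O` differs from compound 1 by the same change, (hydrogen in place of acetyl on an oxygen on a saturated carbon). Going by the values given here, because a 3.0-fold higher number from compound 2 to compound 3 (0.47 log units; beyond the scatter) is the only step of this kind seen so far, the step from compound 1 to compound 4 is expected to be about a 3.0-fold higher number from compound 1 to compound 4 (0.48 log units; beyond the scatter). Compound 4 is therefore estimated at 30 uM in this assay, most likely between 12 uM and 75 uM.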

Compound 4, concentration for half-maximal effect: 11.1 uM
For compound 4 the middle estimate is 2.7-fold (0.43 log units) above the measured one; the whole stated range lies above it.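

In this assay, hydrogen in place of acetyl gave a 1.1-fold higher number from compound 1 to compound 4 (0.05 log units; within the scatter), so on the core of compound 1 this change had no clear effect. This looks smaller than the earlier step, yet the two steps cannot be told apart, so a real dependence on the core is not shown: the same change on two cores in this assay, a 3.0-fold higher number (0.47 log units; beyond the scatter) from compound 2 to compound 3 and a 1.1-fold higher number (0.05 log units; within the scatter) from compound 1 to compound 4, 2.6-fold (0.42 log units) apart, within the scatter of two such steps

Going by these compounds alone, with only two such steps, the data show neither that the change carries over at a fixed size nor that its size depends on the core. On these data alone, whether a methyl ether or a benzoate on that oxygen would behave like the acetyl or like the hydrogen remains open.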